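Exchanging a group on the carbonyl carbon of compound 1

A few compounds are considered here, and "the series" means these few. Any claim that something is new, unique, unknown or untested is made for them only; others in the source may bear on it.

- compound 1 `O=C(NCc1ccc(S(=O)(=O)N2CCCCC2)cc1)c1cc2cnccc2s1`: 15%
- compound 2 `O=C(NCc1ccc(S(=O)(=O)c2cc(F)cc(F)c2)cc1)c1cc2cnccc2[nH]1`: 82%

In an ADME assay on microsomes from liver (Homo sapiens) for metabolic stability, read by LC-MS, with a stated time of 30 min, tested at 1 uM (on this read-out lower numbers stand for a less stable compound and higher numbers for a more stable compound), compound 1 stands lowest of the two measured compounds at 15%, and compound 2 gives 82%. The gap between these two compounds lies outside the usual scatter. Compound 3 `O=C(NCc1ccc(S(=O)(=O)N2CCCCC2)cc1)c1ccc2nc[nH]c2c1` has not yet been measured and carries a single change: a group of 9 heavy atoms (7 carbon, 2 nitrogen; one five-membered aromatic ring with 2 hetero atoms, one six-membered aromatic ring of carbon only) in place of a group of 9 heavy atoms (7 carbon, 1 nitrogen, 1 sulfur; one five-membered aromatic ring with 1 hetero atom, one six-membered aromatic ring with 1 hetero atom), on a carbonyl carbon. Within the data shown here, no pair of measured compounds isolates this change, so the data offer no direct guide to its size. A modest rise is expected, an estimated a number 15 percentage points higher from compound 1 to compound 3 (beyond the scatter). The expected value for compound 3 is 30%, with an estimated range from 12% to 55%.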

Compound 3, percent of the compound remaining: 53%
For compound 3 the middle estimate is 23 percentage points below the measured one, and the stated range covers the measured number.
By their numbers in this assay, from the lowest: compound 1; then compound 3; then compound 2.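

In this assay, among these compounds, putting 1H-benzimidazol-6-yl on the carbonyl carbon gives a number 38 percentage points higher from compound 1 to compound 3 (beyond the scatter) and provides the first comparison in which only this group changes. It shows that this exchange alone, with the rest of compound 1 kept, can move the read-out by a large step. Nothing measured here accounts for the step.

On these data alone, the entering group differs in its ring atoms and its hydrogen-bond donors and acceptors together, so which difference matters remains open. As far as these compounds go, how a plain phenyl ring on this carbonyl carbon would compare also remains open.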